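Swapping the amide substituent of compound 2 for that of compound 1

A few compounds are considered here, and "the series" means these few. Any claim that something is new, unique, unknown or untested is made for them only; others in the source may bear on it.

Measured so far:
- compound 1 `Cc1ccc(NC(=O)CCN(Cc2ccc(C(=O)NO)cc2)C(=O)c2cc(C)cc(C)c2)cc1`: 220 nM
- compound 2 `CN(C)c1ccc(C(=O)N(CCC(=O)NCc2ccc(Cl)cc2)Cc2ccc(C(=O)NO)cc2)cc1`: 390 nM
- compound 3 `COc1ccc(C(=O)N(CCC(=O)NCc2ccccc2)Cc2ccc(C(=O)NO)cc2)cc1`: 1740 nM

All three compounds share a core carrying a hydroxamic acid, and they were tested in a functional assay on SK-N-AS cells (Homo sapiens) for antiproliferative activity, with a stated time of 72 h; on this read-out lower numbers stand for stronger inhibition and higher numbers for weaker inhibition. On these numbers compound 2 stands second highest of three. Its nearest neighbour is compound 1, whose value is lower by an amount that stays within the scatter of repeated measurements, so no order between the two can be claimed. Its furthest neighbour is compound 3, whose value is higher by an amount beyond the scatter, so compound 3 is the weaker of that pair.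

Compound 4 `Cc1ccc(NC(=O)CCN(Cc2ccc(C(=O)NO)cc2)C(=O)c2ccc(N(C)C)cc2)cc1` has not yet been measured. It differs from compound 2 in one place: 4-methylphenyl in place of 4-chlorobenzyl on an amide-type nitrogen. The group that enters is the same amide substituent found in compound 1, while the acyl part of compound 2 is kept. Since compound 1 and compound 2 sit within the scatter of each other, compound 4 is expected to land near both, and the step of a 1.4-fold lower number from compound 2 to compound 4 (0.14 log units; within the scatter) is expected to stay within the scatter. Compound 4 is therefore estimated at 280 nM, with a plausible range from 120 nM to 650 nM.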

Compound 4, half-maximal inhibitory concentration: 400 nM
Compound 4: the middle estimate sits 1.4-fold (0.15 log units) below what was measured; the range from low to high includes it.
By their numbers in this assay, from the lowest: compounds 1, 2 and 4 (each within the scatter of the next); then compound 3.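

In this assay, 4-methylphenyl in place of 4-chlorobenzyl on the amide-type nitrogen gives a 1.0-fold higher number from compound 2 to compound 4 (0.01 log units; within the scatter), so this exchange leaves no readable mark on the antiproliferative result, even though the chlorine goes and the heavy-atom count of the group falls from 8 to 7. With 4-methylphenyl held fixed, 4-(dimethylamino)phenyl in place of 3,5-dimethylphenyl on the carbonyl carbon gives a 1.8-fold higher number from compound 1 to compound 4 (0.26 log units; within the scatter), so the acyl part can also be exchanged here without a readable difference. No independent measurement is available to explain why either exchange leaves the value within the scatter.

Both groups compared on the amide-type nitrogen carry one six-membered aromatic ring of carbon only. The compounds shown therefore leave open what a group without such a ring, such as a simple amine or a carboxylic acid, would do at this position.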